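This account rests on a few compounds, and the source may have more. Where it says the series, first, only, none or still open, it means among the compounds named here.

Compound 1 `O=S(=O)(Cc1nc(-c2cccs2)c2sccc2n1)c1cccc(Cl)c1` was examined in an ADME assay on cells (Homo sapiens) for cytotoxicity, read by resazurin assay, with a stated time of 5 days; on this read-out higher numbers stand for lower toxicity in this test and lower numbers for higher toxicity in this test. In this assay compound 1 gives > 50000 nM, which is a limit of the assay rather than a measured number. Among the measured compounds shown here, compound 2 `COc1ccc(-c2nc(CSc3ccc(C(F)(F)F)cn3)nc3ccsc23)cn1` is the only other compound with a result here. In this assay compound 2 gives > 50000 nM, again a limit. For the measured compounds named here, compound 1 thus stands at the limit together with the one other value, as the limit of > 50000 nM in this assay, at which 2 of the 2 values shown sit, shows. Going by the values given here, no step between two measured compounds is available, and no value has been resolved as a number. Compound 3 `COc1ccc(Oc2nc(CS(=O)(=O)c3cccc(Cl)c3)nc3ccsc23)cc1` has not yet been tested. It differs from compound 1 by 4-methoxyphenoxy in place of thiophen-2-yl on an aromatic carbon. Both known values sit at the same limit. The step of a number no higher from compound 1 to compound 3 (the limit leaves the size open) is expected to be small or none beyond the usual scatter. Compound 3 is therefore estimated to give about 50000 nM, within a range from 20000 nM to 120000 nM, most likely again reported only as a limit.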

Compound 3, half-maximal cytotoxic concentration: > 50000 nM
Compound 3: no number, only a limit (the forecaster's own chance of this, stated with the estimate: 75%); the middle value sits exactly at the limit.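

No step can be read from compound 1 to compound 3, because both results are limits rather than numbers: the limit of > 50000 nM in this assay, at which 3 of the 3 values shown sit.

The compounds shown leave open how far past this limit each one lies, and so whether 4-methoxyphenoxy in place of thiophen-2-yl changes the result at all.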